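Adding a methyl group to a highly active compound

The source may hold more compounds than are shown below. What is called first, only, known or untested is meant among the compounds shown, and "the series" means these compounds.

In a functional assay on OVCAR-3 cells (Homo sapiens) for antiproliferative activity (on this read-out higher numbers stand for weaker inhibition of growth and lower numbers for stronger inhibition of growth), compound 1 `Cc1ccc2c(O)cc(-c3cccc(Cl)c3)nc2n1` gives < 10 nM. That value is a limit of the assay and not a number. Compound 2 `Cc1cccc(-c2cc(O)c3ccc(C)nc3n2)c1` gives 490 nM. Compound 3 `Oc1cc(-c2ccc3ccccc3c2)nc2ncccc12` gives 8320 nM, but no single change connects it to compound 1.

Compound 4 `Cc1cc(C)c2c(O)cc(-c3cccc(Cl)c3)nc2n1` has a methyl in place of hydrogen on an aromatic carbon, opposite the ring nitrogen (methyl in place of hydrogen on an aromatic carbon). Going by the values given here, only one measured step can guide expectations here: an at least 49-fold higher number from compound 1 to compound 2 (1.69 log units; beyond the scatter). This large step, with methyl in place of chloro, shows that one small substitution can matter greatly in this assay. However, it happened at a different place, and compound 4 keeps its chloro group. A smaller step is therefore expected in this assay, probably towards a somewhat higher number, meaning weaker inhibition of growth. The expected change is an at least 2.0-fold higher number from compound 1 to compound 4 (0.30 log units; that floor lies within the scatter). For compound 4 the estimated value is 20 nM, with an expected range from 5 nM to 200 nM.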

Compound 4, concentration for 50% growth inhibition: 170 nM
Beside the measured number, compound 4's estimate is 8.5-fold (0.93 log units) below it; measured number inside the range.
By their numbers in this assay, from the lowest: compound 4; then compound 2; then compound 3. At a limit, below all of these: compound 1.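

In this assay, a methyl group in place of hydrogen on this aromatic carbon, opposite the ring nitrogen, gives an at least 17-fold higher number from compound 1 to compound 4 (1.23 log units; beyond the scatter). Going by these compounds alone, the only earlier step changed the chloro group, whereas this one keeps it, so this second place on compound 1 is also sensitive, even to a single added carbon. The value of compound 1 is a limit of the assay and not a number, so this step gives only a minimum size: the limit of < 10 nM in this assay, at which 1 of the 4 values shown sits.

Methyl is the only group shown replacing this hydrogen, so it remains open how a fluoro group, a methoxy group, an amine or a longer chain such as ethyl would read at this carbon. From the compounds shown here alone, it is also open whether the same added methyl would have a similar effect on compound 2, which carries methyl in place of chloro.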